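The source may hold more compounds than are shown below. What is called first, only, known or untested is meant among the compounds shown, and "the series" means these compounds.

Measured in a functional assay on A549 cells (Homo sapiens) for antiproliferative activity, read by MTT assay, with a stated time of 72 h; on this read-out lower numbers stand for stronger inhibition and higher numbers for weaker inhibition:
- Compound 1 `COc1cc2c(Nc3ccc(C#N)cc3)ncnc2cc1OCCCN(C)C`: 60500 nM
- Compound 2 `COc1cc2c(Nc3ccc(C#N)cc3)ncnc2cc1OCCCN1CCCCC1`: 23500 nM
- Compound 3 `COc1cc2c(Nc3ccc(C#N)cc3)ncnc2cc1OCCCN1CCc2ccccc2C1`: > 100000 nM

For compound 3, > 100000 nM is a limit of this assay and not a number. Its standing therefore rests on (the limit of > 100000 nM in this assay, at which 1 of the 3 values shown sits).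

Compound 4 `CCN1CCN(CCCOc2cc3ncnc(Nc4ccc(C#N)cc4)c3cc2OC)CC1` keeps the shared core and chain and differs from compound 3 at one place: 4-ethylpiperazin-1-yl in place of 1,2,3,4-tetrahydroisoquinolin-2-yl on a saturated chain carbon, three bonds along the chain from an oxygen on an aromatic ring. In words, 4-ethylpiperazin-1-yl comes in place of 1,2,3,4-tetrahydroisoquinolin-2-yl, on a saturated chain carbon, three bonds along the chain from an oxygen on an aromatic ring. The group that leaves brings a six-membered aromatic ring of carbon only, and the group that enters has none.

Three measured steps at this same place bear on the change. They are an at least 4.2-fold higher number from compound 2 to compound 3 (0.62 log units; beyond the scatter), an at least 1.6-fold higher number from compound 1 to compound 3 (0.21 log units; that floor lies within the scatter) and a 2.6-fold lower number from compound 1 to compound 2 (0.41 log units; beyond the scatter). The first of these is the clearest guide, and it suggests that compound 4 should fall back from the limit of compound 3 by a modest step, towards the values of compound 1 and compound 2. A lower number is thus expected, though its size is uncertain with only a limit as the starting point.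

The estimated change is an at least 2.5-fold lower number from compound 3 to compound 4 (0.39 log units; beyond the scatter).

For compound 4 the estimate is 40000 nM, with an expected range of 14000 nM to 100000 nM.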

Compound 4, half-maximal inhibitory concentration: 16000 nM
Estimate against measurement, compound 4: 2.5-fold (0.40 log units) above; low and high end bracket the measured number.
By their numbers in this assay, from the lowest: compounds 4 and 2 (each within the scatter of the next); then compound 1. At a limit, above all of these: compound 3.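

Compound 3 stands at a limit of the assay and not at a number, so any step from it gives only a floor: the limit of > 100000 nM in this assay, at which 1 of the 4 values shown sits. In this assay, the entry of 4-ethylpiperazin-1-yl on this saturated chain carbon gives an at least 6.2-fold lower number from compound 3 to compound 4 (0.79 log units; beyond the scatter), so a larger group at this place does not by itself carry compound 3 to the limit: 4-ethylpiperazin-1-yl, the group with one six-membered non-aromatic ring and no aromatic ring, is tolerated far better than the 1,2,3,4-tetrahydroisoquinolin-2-yl group. Against the other two groups, the result reads as a 1.5-fold lower number from compound 2 to compound 4 (0.17 log units; within the scatter), which leaves 4-ethylpiperazin-1-yl and piperidin-1-yl not told apart, and a 3.8-fold lower number from compound 1 to compound 4 (0.58 log units; beyond the scatter), which adds a second single-ring group that improves on dimethylamino, while compound 3, also a ring-bearing compound, goes against that pattern.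

The compounds shown leave open whether the ethyl group or the ring nitrogen that carries it matters here, which an unsubstituted piperazin-1-yl, a 4-methylpiperazin-1-yl or a morpholin-4-yl group at the same carbon could separate. They also leave open whether the same relation among these groups would hold on a shorter or longer chain.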